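The source may hold more compounds than are shown below. What is called first, only, known or untested is meant among the compounds shown, and "the series" means these compounds.

Four compounds built on one shared core are examined here, and three of them have already been measured in an assay on cell membranes from brain for binding affinity to Adrenergic receptor alpha-1 (Rattus norvegicus), read by radioligand binding; on this read-out lower numbers stand for stronger inhibition and higher numbers for weaker inhibition. Compound 1 `COc1ccccc1N1CCN(CCn2nc(-n3cnc4ccccc43)ccc2=O)CC1` gives 33 nM in this assay. Within the data shown here, compound 2 `COc1ccccc1N1CCN(CCCCCCn2nc(-n3cnc4ccccc43)ccc2=O)CC1` gives 6.4 nM in this assay, the lowest of the three numbers so far; the difference between the cores of compound 1 and compound 2 is not broken down here, and the two values alone show that compound 2 sits well below compound 1. Compound 3 `COc1ccccc1N1CCN(CCn2nc(-n3ccnc3)ccc2=O)CC1` gives 237 nM in this assay.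

The change from compound 1 to compound 3 is 1H-imidazol-1-yl in place of 1H-benzimidazol-1-yl on an aromatic carbon, and it produced a 7.2-fold higher number from compound 1 to compound 3 (0.86 log units; beyond the scatter). The unmeasured compound 4 `COc1ccccc1N1CCN(CCCCCCn2nc(-n3ccnc3)ccc2=O)CC1` carries the same change on the core of compound 2, namely (1H-imidazol-1-yl in place of 1H-benzimidazol-1-yl on an aromatic carbon), with the place described in the same words in both pairs, so it is the same change made on a different starting compound.

On that basis the step from compound 2 to compound 4 in this assay is expected to be close in size to the earlier one: compound 4 is expected to show a 6.6-fold higher number from compound 2 to compound 4 (0.82 log units; beyond the scatter), because compound 1 to compound 3 gave a 7.2-fold higher number from compound 1 to compound 3 (0.86 log units; beyond the scatter). The only support for this is that single pair, so the range is kept broad. Compound 4 is therefore estimated at 42 nM in this assay, expected to lie between 13 nM and 135 nM.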

Compound 4, inhibition constant: 52.5 nM
Beside the measured number, compound 4's estimate is 1.3-fold (0.10 log units) below it; low and high end bracket the measured number.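

In this assay, the new step is an 8.2-fold higher number from compound 2 to compound 4 (0.91 log units; beyond the scatter), for 1H-imidazol-1-yl in place of 1H-benzimidazol-1-yl on an aromatic carbon, and it agrees with the earlier step: the same change on two cores in this assay, a 7.2-fold higher number (0.86 log units; beyond the scatter) from compound 1 to compound 3 and an 8.2-fold higher number (0.91 log units; beyond the scatter) from compound 2 to compound 4, 1.1-fold (0.06 log units) apart, within the scatter of two such steps

On these two cores, then, the change carried over with no difference in size that stands out from the scatter, and the direction was the same on both, with the number rising each time the 1H-benzimidazol-1-yl group gave way to the smaller 1H-imidazol-1-yl group. Among these compounds, this rests on only two pairs in a single assay, so it shows that the step transferred between these two cores, but not that it would transfer to any other core, and it gives no reason for the size of the step.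

The compounds shown leave open whether a different group on the same aromatic carbon, such as an amine or a phenyl group, would fall in line with these two steps. They also leave open whether the step would keep its size on a core with a longer chain, or at any receptor other than the one read here.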